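The compounds below may be only part of what the source reports. "The series", "measured", "known", "first", "only" and "open" are said of these compounds alone.

Measured compounds:
- compound 1, `Cc1ccc(C(=O)NNC(=S)Nc2csc(-c3ccccc3)c2)cc1`, 62000 nM
- compound 2, `COc1cc(C(=O)NNC(=S)Nc2csc(-c3ccccc3)c2)cc(OC)c1OC`, 44000 nM
- compound 3, `COc1ccc(C(=O)NNC(=S)Nc2csc(-c3ccccc3)c2)cc1`, 41000 nM

All three share one core and differ only in the substituents on a single benzene ring. In a functional assay on U-373MG ATCC cells (Homo sapiens) for inhibition, read by colorimetric assay and MTT assay, with a stated time of 72 h (a lower number here means a stronger inhibitor, a higher number a weaker inhibitor), compound 3 gives the smallest of the three numbers, yet neither of the other two is separated from it by more than the usual scatter of this assay: compound 2 sits closest and compound 1 furthest, and both gaps are small.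

Compound 4, `COc1ccc(C(=O)NNC(=S)Nc2csc(-c3ccccc3)c2)cc1OC`, is obtained from compound 3 by the change (methoxy in place of hydrogen on an aromatic carbon). Among the measured compounds shown here, one measured step bears on a change of this kind: a 1.5-fold lower number from compound 1 to compound 3 (0.18 log units; within the scatter), a swap of one small ring substituent for another that did not move the number beyond the scatter. Compound 2, which carries three methoxy groups on the same ring, and compound 3, which carries one, also give numbers that lie within the scatter of each other. Adding one more methoxy group is therefore expected to leave the result in this assay essentially unchanged, with no step beyond the scatter in either direction. Compound 4 is estimated at 40000 nM, between 20000 nM and 80000 nM, which means an expected step of a 1.0-fold lower number from compound 3 to compound 4 (0.01 log units; within the scatter).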

Compound 4, half-maximal inhibitory concentration: 59000 nM
Compound 4: middle estimate off by 1.5-fold (0.17 log units), on the low side; the range from low to high includes it.
By their numbers in this assay, from the lowest: compounds 3, 2, 4 and 1 (each within the scatter of the next).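

In this assay, the position ortho to a methoxy group and meta to a large group now has a direct reading: putting methoxy in place of hydrogen there gives a 1.4-fold higher number from compound 3 to compound 4 (0.16 log units; within the scatter), so this change does not separate the two compounds. The second comparison concerns a different place on the same ring, where hydrogen in place of methoxy gives a 1.3-fold higher number from compound 2 to compound 4 (0.13 log units; within the scatter), and that step does not separate its two compounds either. Each single methoxy change shown therefore stays inside the scatter of this assay, whether the group enters or leaves, and nothing shown offers a reason for this result.

As far as these compounds go, these two comparisons cover only methoxy and hydrogen on this ring, so it remains open whether an amine, a carboxylic acid or a longer chain such as butoxy at the same position would give a step beyond the scatter. Also open, from the compounds shown here alone, is whether changes elsewhere in the shared core, away from this ring, would move the number further than any methoxy change has done here.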